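The source may hold more compounds than are shown below. What is called first, only, known or untested is meant among the compounds shown, and "the series" means these compounds.

Within the data shown here, compound 2 `COC(=O)c1sc2cc(OC)ccc2c1C#Cc1ccc(F)cc1` stands lowest of the two numbers so far in a functional assay on NCI-H460 cells (Homo sapiens) for cytotoxicity, read by sulforhodamine B assay, with a stated time of 48 h (a lower number here means a stronger inhibitor of growth, a higher number a weaker inhibitor of growth), where compound 2 gives 20900 nM. Among the measured compounds shown here, its only neighbour, compound 1 `COC(=O)c1sc2cc(OC)ccc2c1C#Cc1ccccc1`, gives 54900 nM in this assay, and the step of a 2.6-fold lower number from compound 1 to compound 2 (0.42 log units; beyond the scatter) is the single measured step available. Compound 3 `COC(=O)c1sc2cc(OC)ccc2c1C#Cc1ccccc1F` is the next compound to be measured in this assay. It differs from compound 2 in one place: 2-fluorophenyl in place of 4-fluorophenyl on a triple-bonded carbon. For the measured compounds named here, the measured step bears on this only loosely, since it shows what fluoro in place of hydrogen does, not what moving the fluorine within the ring does; no measured pair shows such a shift. Compound 3 is therefore expected to stand close to compound 2, with a step of a 1.3-fold higher number from compound 2 to compound 3 (0.13 log units; within the scatter) that may stay within the scatter or drift modestly upward. The estimate for compound 3 in this assay is 28000 nM, within a range from 9000 nM to 85000 nM.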

Compound 3, concentration for 50% growth inhibition: 7200 nM
Beside the measured number, compound 3's estimate is 3.9-fold (0.59 log units) above it; the measured number lies below the stated range.
By their numbers in this assay, from the lowest: compound 3; then compound 2; then compound 1.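

In this assay, the place of the fluorine on the ring matters and not only its presence: 2-fluorophenyl in place of 4-fluorophenyl gives a 2.9-fold lower number from compound 2 to compound 3 (0.46 log units; beyond the scatter) with no change in the atoms present. Fluoro in place of hydrogen on an aromatic carbon also gives a 7.6-fold lower number from compound 1 to compound 3 (0.88 log units; beyond the scatter) in this second ring place, so both fluorinated compounds lie below the unsubstituted phenyl of compound 1, and compound 3 is the strongest inhibitor of growth of the three. No measurement shown here explains why the 2-fluorophenyl compound stands lowest. The compounds shown leave open whether this gain belongs to fluorine alone. A chloro, methoxy or amino group in the place held by the fluorine of compound 3 could test this.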